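The source may hold more compounds than are shown below. What is called first, only, known or untested is meant among the compounds shown, and "the series" means these compounds.

Measured compounds:
Compound 1 `CCC(=O)N1CCN(c2nnc3nncn3n2)CC1`: 10100 nM
Compound 2 `c1nnc2nnc(N3CCCCC3)nn12`: 23600 nM
Compound 3 `c1nnc2nnc(N3CCCC3)nn12`: 24400 nM

In a functional assay on HL-60 cells (Homo sapiens) for inhibition, read by MTT assay, with a stated time of 72 h (a higher number here means a weaker inhibitor, a lower number a stronger inhibitor), compound 1 has the lowest of the three numbers at 10100 nM, and its gaps to compound 2 and compound 3 lie beyond the scatter. Compound 4 `CCCCC(=O)N1CCN(c2nnc3nncn3n2)CC1` keeps the core of compound 1 and changes only the chain on the carbonyl, from propanoyl to butylcarbonyl: ethyl in place of hydrogen on a saturated chain carbon, two bonds along the chain from a carbonyl carbon. Going by the values given here, no measured pair of compounds varies this chain, which leaves the expectation without direct support. In this assay, the estimated step, a 1.0-fold lower number from compound 1 to compound 4 (0.00 log units; within the scatter), is expected to stay within the scatter. Compound 4 is expected at 10000 nM, with an estimated range of 4500 nM to 22000 nM.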

Compound 4, half-maximal inhibitory concentration: 3130 nM
For compound 4 the middle estimate is 3.2-fold (0.50 log units) above the measured one; measured number below the stated range.
By their numbers in this assay, from the lowest: compound 4; then compound 1; then compounds 2 and 3 (each within the scatter of the next).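

In this assay, going by these compounds alone, ethyl in place of hydrogen on a saturated chain carbon, two bonds along the chain from a carbonyl carbon, gives a 3.2-fold lower number from compound 1 to compound 4 (0.51 log units; beyond the scatter) and so provides the first measured step at this position. It shows that the number responds to the chain on the carbonyl while the core of compound 1 stays the same. No available evidence accounts for this step.

On these data alone, a single step sets no trend, so it remains open whether a longer chain would lower the number further. As far as these compounds go, the effect of a branched chain, a phenyl ring or a terminal amine at this place also remains open.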